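Swapping an Alkyne Tail Ending: Ethyl to Chloro

The compounds below may be only part of what the source reports. "The series", "measured", "known", "first", "only" and "open" are said of these compounds alone.

Three close relatives share one core and differ only in the group attached to an aromatic carbon. Compound 1 `O=c1[nH]c(=O)n(CCC(CO)CO)cc1-c1ccco1` carries a furan-2-yl group. In a functional assay on SW-620 cells (Homo sapiens) for antiproliferative activity, read by MTT assay, with a stated time of 72 h (on this read-out higher numbers stand for weaker inhibition and lower numbers for stronger inhibition), compound 1 gives > 100000 nM, which is a limit of the assay and not a number. Compound 2 `O=c1[nH]c(=O)n(CCC(CO)CO)cc1-c1cccs1` carries a thiophen-2-yl group; in this assay compound 2 gives > 100000 nM, again a limit. Compound 3 `CCCCCC#Cc1cn(CCC(CO)CO)c(=O)[nH]c1=O` carries a hept-1-yn-1-yl group; in this assay compound 3 gives > 100000 nM, also a limit. Because all three sit at the limit of > 100000 nM in this assay, at which 3 of the 3 values shown sit, the steps a step that the two limits leave unreadable from compound 1 to compound 2, a step that the two limits leave unreadable from compound 1 to compound 3 and a step that the two limits leave unreadable from compound 2 to compound 3 cannot be sized. Compound 3 therefore stands only at a limit, with no number among its companions to rank it against. Compound 4 `O=c1[nH]c(=O)n(CCC(CO)CO)cc1C#CCCCCl` differs from compound 3 by chloro in place of ethyl on a saturated chain carbon, three bonds along the chain from a triple-bonded carbon. Among the compounds with values here, no measured step bears on this change, since every step here is unreadable. The step from compound 3 to compound 4 is expected to be a number no higher from compound 3 to compound 4 (the limit leaves the size open), that is, nothing beyond the scatter. Compound 4 is expected to give 100000 nM, between 40000 nM and 300000 nM, most likely reported again as a limit.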

Compound 4, half-maximal inhibitory concentration: > 100000 nM
Compound 4: only a limit was reported; the forecaster's own chance of this, stated with the estimate: 85%; the middle value sits exactly at the limit.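

Within the data shown here, no step from compound 4 to compound 1, compound 2 or compound 3 can be read, because all four compounds stop at the same limit of the assay, which is not a number: the limit of > 100000 nM in this assay, at which 4 of the 4 values shown sit. On these data alone, whether chloro in place of ethyl changes antiproliferative activity at all stays open, as does how these four compounds rank against one another.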